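The source may hold more compounds than are shown below. What is called first, only, known or untested is meant among the compounds shown, and "the series" means these compounds.

Compound 1, drawn as `Oc1cccc(-c2cc(-c3ccncc3)nc(-c3cccc(Cl)c3)c2)c1`, has no single number in a functional assay on HCT-15 cells (Homo sapiens) for cytotoxicity, read by CCK-8 assay and cell counting, with a stated time of 2 days; a higher number here means a weaker inhibitor, a lower number a stronger inhibitor: its entry there reads "not determined" (no result reported). Compound 2, `Oc1ccc(-c2cc(-c3ccncc3)nc(-c3cccc(Cl)c3)c2)cc1`, stands the same way, with "not determined" (no result reported) in this assay. Only compound 3, `Oc1cccc(-c2cc(-c3ccncc3)nc(-c3ccc(Cl)cc3)c2)c1`, carries a figure, giving 2630 nM in this assay. Compound 4, `Oc1cccc(-c2cc(-c3ccccc3)nc(-c3cccc(Cl)c3)c2)c1`, differs from compound 1 by one change: phenyl in place of pyridin-4-yl on an aromatic carbon. Among the measured compounds shown here, no measured pair shows what this exchange does, so no direction can be read from the data, and a step beyond the scatter is possible either way. Compound 4 is therefore expected, with wide uncertainty, to give about 3500 nM in this assay, somewhere between 800 nM and 15000 nM.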

Compound 4, half-maximal inhibitory concentration: 2550 nM
Compound 4: the middle estimate sits 1.4-fold (0.14 log units) above what was measured; low and high end bracket the measured number.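

Compound 1 has no single number to set against compound 4, so no step can be read between them, and no measured evidence bears on this result. As far as these compounds go, what phenyl in place of pyridin-4-yl does in this assay stays open.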